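From 2-bromophenoxy to (2-bromophenyl)sulfanyl in a cell assay

A few compounds are considered here, and "the series" means these few. Any claim that something is new, unique, unknown or untested is made for them only; others in the source may bear on it.

Among the compounds with values here, only two compounds sharing one core have been tested so far, and neither has yielded an exact figure. In an ADME assay on MCF7 cells (Homo sapiens) for inhibition (a lower number here means a stronger inhibitor, a higher number a weaker inhibitor), compound 1 (`COC(=O)c1cc2c(F)c(F)c(-n3ccnc3)c(F)c2s1`) gives > 100000 nM as a limit of the assay and not a number. Compound 2 (`COC(=O)c1cc2c(F)c(F)c(Oc3ccccc3Br)c(F)c2s1`) gives > 25000 nM as a limit too, so it has no exact place on the scale. Within the data shown here, the one measured change is a step that the two limits leave unreadable from compound 1 to compound 2 and so offers no size to carry forward.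

Compound 3 (`COC(=O)c1cc2c(F)c(F)c(Sc3ccccc3Br)c(F)c2s1`) carries (2-bromophenyl)sulfanyl in place of 2-bromophenoxy on an aromatic carbon. With no readable step to lean on, nothing points to a shift in either direction in this assay, and the expectation is no move beyond the scatter. The estimate rests on compound 2 alone, whose > 25000 nM is a limit. The expected change is a step that the limit leaves unreadable from compound 2 to compound 3 and no more than the usual scatter. Compound 3 is estimated at 30000 nM with an expected range from 12000 nM to 100000 nM. Another limit rather than an exact figure is expected for compound 3.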

Compound 3, half-maximal inhibitory concentration: > 25000 nM
Compound 3: no number, only a limit; the forecaster's own chance of this, stated with the estimate: 65%; the middle value lies beyond the limit too.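

Compound 3 also ends at a limit in this assay, so the steps linking compound 1, compound 2 and compound 3 cannot be read, and none has a size. The compounds shown leave open how strongly each one inhibits, and whether 2-bromophenoxy and (2-bromophenyl)sulfanyl differ at all in this assay.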